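Chloro substitution on the benzyl ether of compound 1

The source may report more compounds than this note shows. Statements on the series, on what has been measured and on what is new or still open speak of the compounds shown alone.

Within the data shown here, compound 1 `Cc1cc(C(=O)O)nn1Cc1cc(Br)ccc1OCc1ccccc1` gives in an assay on CHO-K1 cells for displacement of a labelled ligand from prostaglandin E2 receptor EP1 subtype (Homo sapiens) (on this read-out higher numbers stand for weaker inhibition and lower numbers for stronger inhibition), a value of 6.46 nM, the lowest of the three numbers measured so far. Compound 2 `O=C(O)c1ccn(Cc2cc(Br)ccc2OCc2ccccc2)n1` gives in this assay 9.77 nM; the step of a 1.5-fold higher number from compound 1 to compound 2 (0.18 log units; within the scatter) lies within the scatter, so no order between these two compounds is claimed. Compound 3 `Cc1cn(Cc2cc(Br)ccc2OCc2ccccc2)nc1C(=O)O` gives in this assay 427 nM, and the step of a 44-fold higher number from compound 2 to compound 3 (1.64 log units; beyond the scatter) is large.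

Compound 4 `Cc1cc(C(=O)O)nn1Cc1cc(Br)ccc1OCc1ccc(Cl)cc1` differs from compound 1 by chloro in place of hydrogen on an aromatic carbon: phenyl to 4-chlorophenyl, benzyl to 4-chlorobenzyl, on the six-membered aromatic ring of carbon only, para to a large group.

Both measured steps concern a methyl on the shared core, not the benzyl ether, so neither bears directly on the change from compound 1 to compound 4. The series holds no other change at the benzyl ether, and the expectation therefore rests on the lack of any contrary evidence rather than on a measured precedent. No step beyond the scatter is expected; the step expected is a 1.0-fold higher number from compound 1 to compound 4 (0.00 log units; within the scatter). For compound 4 the estimate in this assay is 6.5 nM, with a range from 2.5 nM to 18 nM.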

Compound 4, half-maximal inhibitory concentration: 8.71 nM
Estimate against measurement, compound 4: 1.3-fold (0.13 log units) below; low and high end bracket the measured number.
By their numbers in this assay, from the lowest: compounds 1, 4 and 2 (each within the scatter of the next); then compound 3.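

At the benzyl ether the series now has its first measured change: chloro in place of hydrogen on an aromatic carbon, para to a large group, gives a 1.3-fold higher number from compound 1 to compound 4 (0.13 log units; within the scatter) in this assay, so this substitution leaves the number within the scatter. The earlier steps shown here concerned only a methyl on the shared core, where one of them, a 44-fold higher number from compound 2 to compound 3 (1.64 log units; beyond the scatter), is large, whereas this single chlorine on the six-membered aromatic ring of carbon only is accommodated with no change that can be read. No measurement bearing on the reason for this outcome is available.

A single group at a single place does not settle what a methoxy, a trifluoromethyl or a carboxylic acid would do there, nor whether chloro on another carbon of the same ring would keep the number in this range. Also open, going by these compounds, is whether 4-chlorobenzyl in place of benzyl would give a similar result on the core of compound 2 or compound 3, the latter already standing well apart from the other compounds.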